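The compounds below may be only part of what the source reports. "The series", "measured", "known", "first", "only" and "open" are said of these compounds alone.

Measured so far:
Compound 1 `CCC(=O)[C@H](CCCNC(=N)N)NC(=O)[C@@H]1CCCN1C(=O)[C@@H](NC(=O)[C@H](CC(C)C)NC(=O)OCc1ccccc1)C(C)C`: > 20000 nM (a limit)
Compound 2 `CC(C)[C@@H](C(=O)N1CCC[C@H]1C(=O)N[C@@H](CCCNC(=N)N)C(=O)CF)N(C)C(=O)OCc1ccccc1`: > 20000 nM (a limit)

Both readings come from a functional assay on OCI-Ly3 cells (Homo sapiens) for inhibition, read by CellTiter-Glo, with stated times of 48 h and 96 h; on this read-out lower numbers stand for stronger inhibition of growth and higher numbers for weaker inhibition of growth. Compound 2 stands at > 20000 nM, which is a limit of the assay and not a number. Compound 1 is in the same position, and the evidence so far amounts to the limit of > 20000 nM in this assay, at which 2 of the 2 values shown sit. Among the measured compounds shown here, neither compound has a measured growth inhibition, and the data hold no step between measured compounds to scale from.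

Compound 3 `CC(C)[C@H](NC(=O)c1ccc(Br)cc1)C(=O)N1CCC[C@H]1C(=O)N[C@@H](CCCNC(=N)N)C(=O)CF` has not yet been measured. It differs from compound 2 in one place: ((4-bromophenyl)carbonyl)amino in place of (benzyloxycarbonyl)(methyl)amino on a saturated chain carbon bound to a carbonyl carbon and a saturated chain carbon. The swap keeps one six-membered aromatic ring of carbon only, and the rest of the structure stays the same.

A large gain in growth inhibition is not expected, and this expectation rests on compound 2 with its > 20000 nM, again a limit. The estimated change is a number no higher from compound 2 to compound 3 (the limit leaves the size open), expected to be none beyond the usual scatter. Compound 3 is estimated at 20000 nM, with an expected range from 8000 nM to 40000 nM, and it may well be reported only as a limit.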

Compound 3, concentration for 50% growth inhibition: 130 nM
For compound 3 the middle estimate is 150-fold (2.19 log units) above the measured one; measured number outside the range, below it.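

The earlier compounds shown here gave no sign that the group on a saturated chain carbon bound to a carbonyl carbon and a saturated chain carbon could matter in this assay, yet putting ((4-bromophenyl)carbonyl)amino in place of (benzyloxycarbonyl)(methyl)amino brings an at least 150-fold lower number from compound 2 to compound 3 (2.18 log units; beyond the scatter). The full size of this step cannot be read: compound 2 gives > 20000 nM, which is a limit of the assay and not a number. The swap keeps one six-membered aromatic ring of carbon only and the rest of the structure, so this one place decides between a measured growth inhibition and a reading at the limit, where the other values remain: the limit of > 20000 nM in this assay, at which 2 of the 3 values shown sit.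

The compounds shown do not separate the share of the bromine from that of the lost methyl on the nitrogen or of the change from the benzyloxycarbonyl group to the bromophenyl carbonyl group. They also leave open how a chlorine, an amine or a carboxylic acid in place of the bromine would read in this assay.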